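One Methyl Group, Two Cores, One Open Question

This account rests on a few compounds, and the source may have more. Where it says the series, first, only, none or still open, it means among the compounds named here.

Of the compounds shown here, three have been measured in a functional assay on the whole organism for agonist activity, with Mus musculus as the target; on this read-out higher numbers stand for an effect only at larger amounts of compound and lower numbers for an effect already at smaller amounts.
Compound 1 `CC1CCC(=O)N1CC#CCn1ccnc1` gives > 100 mg/kg, which is a limit of the assay and not a number.
Compound 2 `Cc1cncn1CC#CCN1C(=O)CCC1C` gives > 100 mg/kg, also a limit of the assay rather than a number.
For the measured compounds named here, compound 3 `CN1CCN(CC#CCn2ccnc2)C1=O` gives 1.4 mg/kg, the only number among the three.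

Compound 2 differs from compound 1 by methyl in place of hydrogen on an aromatic carbon. The step that the two limits leave unreadable from compound 1 to compound 2 cannot be read because of the limit of > 100 mg/kg in this assay, at which 2 of the 3 values shown sit. The difference between the two cores, that of compound 1 and that of compound 3, is not broken down here. Compound 4 `Cc1cncn1CC#CCN1CCN(C)C1=O`, not yet measured, carries the same change on the core of compound 3: methyl in place of hydrogen on an aromatic carbon. The place of the change is described in the same words for both pairs, so it is the same change. The measured compounds give no readable size for this change. For compound 4 in this assay a moderate step of a 2.9-fold higher number from compound 3 to compound 4 (0.46 log units; beyond the scatter) is expected, resting on compound 3 with 1.4 mg/kg as the starting point. Compound 4 is estimated at 4 mg/kg, with a range from 1 mg/kg to 40 mg/kg.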

Compound 4, dose for half-maximal effect: > 100 mg/kg
Compound 4 gave a limit, no number; the forecaster's own chance of this, stated with the estimate: 20%; middle value at least 25-fold (1.39 log units) from the limit.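

In this assay, putting methyl in place of hydrogen on an aromatic carbon of the core of compound 3 gives an at least 71-fold higher number from compound 3 to compound 4 (1.85 log units; beyond the scatter). Compound 4 gives > 100 mg/kg, which is a limit of the assay and not a number, so this single added carbon is enough on this core to move the read-out from a measured dose to that limit. Whether the change acts to the same extent on both cores remains unshown, because the matching step on the core of compound 1 cannot be read: the limit of > 100 mg/kg in this assay, at which 3 of the 4 values shown sit.

The compounds shown leave open whether a group other than methyl on that same aromatic carbon, such as an ethyl group or an amine, would keep the effect at doses like that of compound 3, at 1.4 mg/kg. They also leave open how any such group would behave on the core of compound 1, where a readable starting value is still missing.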